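The source may report more compounds than this note shows. Statements on the series, on what has been measured and on what is new or still open speak of the compounds shown alone.

Compound 1 `O=[N+]([O-])c1ccc(-c2nnc(-c3cccnc3)o2)cc1`: 73.5 ug/mL
Compound 2 `O=[N+]([O-])c1ccc(-c2nnc(-c3cccnc3)n2Nc2nc3ccc(Br)cc3s2)cc1`: 13.2 ug/mL

Among the measured compounds shown here, in an ADME assay on MT4 cells (Homo sapiens) for cytotoxicity, read by MTT assay, with a stated time of 5 days (a lower number here means that less compound is tolerated, a higher number that more compound is tolerated), compound 2 stands at the lower of the two numbers known so far; compound 1, the only other measured compound, gives a higher number in this assay, and the gap between the two lies beyond the scatter. Compound 3 `COc1ccc2nc(Nn3c(-c4ccc([N+](=O)[O-])cc4)nnc3-c3cccnc3)sc2c1` differs from compound 2 in one place: methoxy in place of bromo on an aromatic carbon. For the measured compounds named here, no measured pair shows this particular exchange, so the size of the step has to be judged without a precedent. The step from compound 2 to compound 3 is expected to be small, with no clear direction, and most likely to stay within the scatter of the method, as a 1.1-fold higher number from compound 2 to compound 3 (0.06 log units; within the scatter). On that basis compound 3 is estimated to give 15 ug/mL in this assay, with a range from 6 ug/mL to 40 ug/mL.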

Compound 3, half-maximal cytotoxic concentration: 12.9 ug/mL
The estimate for compound 3 lay 1.2-fold (0.07 log units) above the measured number, and the stated range covers the measured number.
By their numbers in this assay, from the lowest: compounds 3 and 2 (each within the scatter of the next); then compound 1.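

Among the compounds shown here, measured in this assay, methoxy in place of bromo on this aromatic carbon gives a 1.0-fold lower number from compound 2 to compound 3 (0.01 log units; within the scatter), the first measured instance of this exchange. At this position, the two substituents therefore cannot be told apart in this assay, even though methoxy carries a hydrogen-bond acceptor and bromo does not. No supporting measurement bears on why the exchange leaves the number within the scatter.

This single pair leaves open whether a group of another kind at the same aromatic carbon, such as an amine or a carboxylic acid, would move the number beyond the scatter. It also leaves open whether methoxy in place of bromo would behave the same way at another carbon of this ring, or on a different core.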